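Notes on the series: from compound 2 to compound 3

The source may hold more compounds than are shown below. What is called first, only, known or untested is meant among the compounds shown, and "the series" means these compounds.

Compound 1 `CCCCCCN1CCC(C(=O)Nc2cc(Cl)c(N)cc2OC)CC1` gives > 10 mg/kg in a functional assay on the whole organism for antagonist activity, with Mus musculus as the target; a lower number here means that less compound is needed, a higher number that more compound is needed for the effect; this is a limit of the assay.
Compound 2 `COc1cc(N)c(Cl)cc1NC(=O)C1CCN(C/C=C/c2ccccc2)CC1` gives > 10 mg/kg in this assay; this too is a limit.

Compound 2 therefore stands at the limit only, with no number of its own; both measured values sit there, as the limit of > 10 mg/kg in this assay, at which 2 of the 2 values shown sit, shows. Among the measured compounds shown here, the one measured step, a step that the two limits leave unreadable from compound 1 to compound 2, cannot be read, since each end is a limit.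

Compound 3 `COc1cc(N)c(Cl)cc1NC(=O)C1CCN(Cc2ccc([N+](=O)[O-])cc2)CC1` differs from compound 2 in one place: 4-nitrophenyl in place of 2-phenylethenyl on a saturated chain carbon bound to an amine nitrogen in a ring. For the measured compounds named here, no measured step bears on this exchange, and no step size beyond the scatter can be expected from the data in either direction. On that basis the step that the limit leaves unreadable from compound 2 to compound 3 is expected to stay unreadable, with compound 3 most likely again reported as a limit.

The estimate for compound 3 in this assay is 15 mg/kg, with a range from 4 mg/kg to 60 mg/kg.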

Compound 3, dose for half-maximal effect: > 4 mg/kg
Compound 3 gave a limit, no number; the forecaster's own chance of this, stated with the estimate: 75%; the middle value lies beyond the limit too.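

No new step can be read: compound 3, like compound 1 and compound 2, is reported only as a limit, and its comparisons with both remain unreadable. The compounds shown leave open what dose of any of the three gives the half-maximal effect in this assay.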